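Difluorobenzyl swap at the limit of the series

The compounds below may be only part of what the source reports. "The series", "measured", "known", "first", "only" and "open" are said of these compounds alone.

Measured in a functional assay on K562 cells (Homo sapiens) for antiproliferative activity, with a stated time of 72 h; on this read-out higher numbers stand for weaker inhibition and lower numbers for stronger inhibition:
- compound 1 `OC[C@H]1O[C@@H](n2cnc3c(NCc4ccc(Cl)cc4)ncnc32)[C@H](O)[C@@H]1O`: 218000 nM
- compound 2 `COc1cccc(CNc2ncnc3c2ncn3[C@@H]2O[C@H](CO)[C@@H](O)[C@H]2O)c1OC`: > 166000 nM (a limit)

Compound 2 has only a limit, > 166000 nM, not a number. Compound 3 `OC[C@H]1O[C@@H](n2cnc3c(NCc4ccc(F)cc4F)ncnc32)[C@H](O)[C@@H]1O` differs from it as follows: 2,4-difluorophenyl in place of 2,3-dimethoxyphenyl on a saturated chain carbon bound to a nitrogen on an aromatic ring. Among the measured compounds shown here, the only measured step that bears on this change is a step that the limit leaves unreadable from compound 1 to compound 2, so no size carries over from it. For the measured compounds named here, the expectation therefore rests on compound 1 at 218000 nM, the sole number in this assay, and no step beyond the scatter is expected. The expected step is a step that the limit leaves unreadable from compound 2 to compound 3. The estimate for compound 3 is 180000 nM, with an expected range of 70000 nM to 400000 nM.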

Compound 3, half-maximal inhibitory concentration: 9600 nM
Compound 3: middle estimate off by 19-fold (1.27 log units), on the high side; measured number outside the range, below it.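

In this assay, the group on a saturated chain carbon bound to a nitrogen on an aromatic ring clearly changes the read-out: 2,4-difluorophenyl in place of 4-chlorophenyl gives a 23-fold lower number from compound 1 to compound 3 (1.36 log units; beyond the scatter), and in place of 2,3-dimethoxyphenyl gives an at least 17-fold lower number from compound 2 to compound 3 (1.23 log units; beyond the scatter). The step from compound 1 to compound 2 cannot be read, so these two steps alone give a size at this position. Compound 2 has only a limit, so its step is a bound: the limit of > 166000 nM in this assay, at which 1 of the 3 values shown sits.

Going by these compounds, whether both fluorines are needed remains open, as a monofluorophenyl group would test that. Also open, on these data alone, is how a longer chain between the nitrogen and the 2,4-difluorophenyl ring would read.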